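A few compounds are considered here, and "the series" means these few. Any claim that something is new, unique, unknown or untested is made for them only; others in the source may bear on it.

Working notes on the series, read in a functional assay on HUVEC cells (Homo sapiens), read by MTT assay, with a stated time of 24 h; a lower number here means a stronger inhibitor, a higher number a weaker inhibitor. Compound 1 `COc1ccc(-c2cnc3cc(C)c(C)cc3n2)cc1O` is reported only as a limit, > 100000 nM. Compound 2 `Cc1cc2ncc(-c3ccc(OCc4ccccc4)c(O)c3)nc2cc1C` is also reported only as a limit, > 100000 nM. For the measured compounds named here, compound 2 therefore stands at the limit of > 100000 nM in this assay, at which 2 of the 2 values shown sit, and the series so far holds no exact value.

Compound 3 `CC(=O)Oc1ccc(-c2cnc3cc(C)c(C)cc3n2)cc1O` is the next structure to read against compound 2. The change is acetyl in place of benzyl on an oxygen on an aromatic ring, so benzyloxy gives way to acetoxy on the same oxygen.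

Going by the values given here, only one measured step bears on this change, and it also alters the group on an oxygen on an aromatic ring: a step that the two limits leave unreadable from compound 1 to compound 2. It gives no size and no direction to carry over to this assay. With no readable step as a guide, no clear shift is expected, and a further limit is the likeliest report. The expected step is a number no higher from compound 2 to compound 3 (the limit leaves the size open), an estimate set against a limit and not against an exact value. Compound 3 is estimated at 100000 nM, with an expected range of 25000 nM to 200000 nM.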

Compound 3, half-maximal inhibitory concentration: 54400 nM
Compound 3: the middle estimate sits 1.8-fold (0.26 log units) above what was measured, and the stated range covers the measured number.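

Compound 3 gives the series its first exact number in this assay, so a change on this oxygen on an aromatic ring can now be given a floor, which the earlier pair could not provide. Acetyl in place of benzyl gives an at least 1.8-fold lower number from compound 2 to compound 3 (0.26 log units; that floor lies within the scatter) and acetyl in place of methyl gives an at least 1.8-fold lower number from compound 1 to compound 3 (0.26 log units; that floor lies within the scatter) and, as both steps start from a limit, each gives only a minimum size that does not clear the usual scatter, so acetyl is not yet shown to differ from either group. The step from compound 1 to compound 2 remains unreadable, and compound 1 and compound 2 are still limits and not numbers: the limit of > 100000 nM in this assay, at which 2 of the 3 values shown sit.

Going by these compounds, the true size of both steps stays open, and so does whether anything beyond acetyl itself matters, since one exact value cannot separate an effect of the carbonyl from an effect of the smaller group. A longer acyl chain, such as propionyl, or an amine-bearing chain on the same oxygen would be needed to show whether the number in this assay moves beyond the scatter.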